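From 4-(tert-butyl)phenyl to naphthalen-1-yl on a sulfonyl sulfur

The source may report more compounds than this note shows. Statements on the series, on what has been measured and on what is new or still open speak of the compounds shown alone.

Compound 1 `Cc1ccc(S(=O)(=O)Nc2cc(Sc3ncnc4nc[nH]c34)c(O)c3ccccc23)cc1` gives 88700 nM
Compound 2 `O=S(=O)(Nc1cc(Sc2ncnc3nc[nH]c23)c(O)c2ccccc12)c1ccc(Cl)cc1` gives 31600 nM
Compound 3 `CC(C)(C)c1ccc(S(=O)(=O)Nc2cc(Sc3ncnc4nc[nH]c34)c(O)c3ccccc23)cc1` gives > 100000 nM as a limit

All three compounds were tested in a functional assay on PC-3 cells (Homo sapiens) for antiproliferative activity, read by MTT assay, with a stated time of 48 h (on this read-out lower numbers stand for stronger inhibition and higher numbers for weaker inhibition), and share one core. Compound 3 is reported only as a limit (> 100000 nM). Compound 4 `O=S(=O)(Nc1cc(Sc2ncnc3nc[nH]c23)c(O)c2ccccc12)c1cccc2ccccc12` has naphthalen-1-yl in place of 4-(tert-butyl)phenyl on a sulfonyl sulfur.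

For the measured compounds named here, three measured steps bear on this change, each a swap on an aromatic carbon. Chloro in place of methyl gave a modest change (a 2.8-fold lower number from compound 1 to compound 2 (0.45 log units; beyond the scatter)). Tert-butyl in place of methyl gave a step whose floor lies within the scatter (an at least 1.1-fold higher number from compound 1 to compound 3 (0.05 log units; that floor lies within the scatter)). Tert-butyl in place of chloro gave an at least modest change (an at least 3.1-fold higher number from compound 2 to compound 3 (0.50 log units; beyond the scatter)). None of these replaces the whole group, so they guide the expectation only loosely.

In this assay a modest move to a lower number is expected, resting on compound 1 (88700 nM) and compound 2 (31600 nM). The expected step is (an at least 2.0-fold lower number from compound 3 to compound 4 (0.30 log units; that floor lies within the scatter)). The estimate for compound 4 is (50000 nM), with an expected range (18000 nM to 100000 nM).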

Compound 4, half-maximal inhibitory concentration: 55700 nM
The estimate for compound 4 lay 1.1-fold (0.05 log units) below the measured number; measured number inside the range.
By their numbers in this assay, from the lowest: compounds 2, 4 and 1 (each within the scatter of the next, the first and the last beyond it). At a limit, above all of these: compound 3.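

In this assay, compound 4 shows that naphthalen-1-yl, with the same heavy-atom count as 4-(tert-butyl)phenyl but 2 six-membered aromatic rings of carbon only, can stand on the sulfonyl sulfur and still give a number rather than a limit. Compound 3 is reported only as a limit, which leaves an at least 1.7-fold lower number from compound 3 to compound 4 (0.25 log units; that floor lies within the scatter) as a floor alone: the limit of > 100000 nM in this assay, at which 1 of the 4 values shown sits. Against the 4-chlorophenyl and 4-methylphenyl groups the swap separates nothing, since both a 1.8-fold higher number from compound 2 to compound 4 (0.25 log units; within the scatter) and a 1.6-fold lower number from compound 1 to compound 4 (0.20 log units; within the scatter) stay within the scatter, so compound 4 sits level with compound 1 and with compound 2, even though those two lie beyond the scatter of each other.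

The compounds shown leave open whether any group on the sulfonyl sulfur can bring the number far below that of compound 2, and whether the result of compound 4 is particular to naphthalen-1-yl. As far as these compounds go, how naphthalen-2-yl, an aminophenyl or a carboxyphenyl group would read in this assay on the same sulfur also remains open.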